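Shortening the Side Chain of Compound 3

The source may hold more compounds than are shown below. What is called first, only, known or untested is meant among the compounds shown, and "the series" means these compounds.

In a functional assay (trachea) with Cavia porcellus as the target (on this read-out lower numbers stand for an effect already at smaller amounts and higher numbers for an effect only at larger amounts of compound), compound 3 `CCCn1c(=O)n(CCOC)c(=O)c2[nH]cnc21` gives 700 nM and compound 1 `CCCn1c(=O)n(CC)c(=O)c2[nH]cnc21` gives 1300 nM, two values within the scatter of each other. Compound 2 `CCCn1c(=O)n(CC(=O)O)c(=O)c2[nH]cnc21` stands far from both at 41000 nM, and the gap to the best-placed pair shows in a 59-fold lower number from compound 2 to compound 3 (1.77 log units; beyond the scatter). The next compound, compound 4 `CCCn1c(=O)n(C)c(=O)c2[nH]cnc21`, has hydrogen in place of methoxymethyl on a saturated chain carbon bound to an aromatic nitrogen. The closest evidence is a 1.9-fold lower number from compound 1 to compound 3 (0.27 log units; within the scatter), a methoxy change that stayed within the scatter. The large step of a 32-fold higher number from compound 1 to compound 2 (1.50 log units; beyond the scatter) involves a carboxy group, which plays no part in the new change, so it offers little guidance. In this assay, a small step toward a higher number is therefore expected, not clearly beyond the scatter. The estimate for compound 4 is 1300 nM, with an expected range from 450 nM to 4000 nM. This estimate means a 1.9-fold higher number from compound 3 to compound 4 (0.27 log units; within the scatter).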

Compound 4, half-maximal effective concentration: 1600 nM
Beside the measured number, compound 4's estimate is 1.2-fold (0.09 log units) below it, within the range that was stated.
By their numbers in this assay, from the lowest: compounds 3, 1 and 4 (each within the scatter of the next, the first and the last beyond it); then compound 2.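

Replacing the methoxymethyl group on this saturated chain carbon bound to an aromatic nitrogen gives a modest step in this assay that clears the scatter, a 2.3-fold higher number from compound 3 to compound 4 (0.36 log units; beyond the scatter), so the 2-methoxyethyl and methyl chains can be told apart here. Hydrogen in place of methyl gives a 1.2-fold higher number from compound 1 to compound 4 (0.09 log units; within the scatter), so the methyl and ethyl chains cannot be told apart, while hydrogen in place of carboxy gives a large step, a 26-fold lower number from compound 2 to compound 4 (1.41 log units; beyond the scatter), which shows that even the shortest chain shown stands far from the carboxy compound. Nothing available beyond these numbers speaks to why the steps fall as they do. The compounds shown leave open how a longer chain such as butyl would read at this position. They also leave open how an amine or an ester at the end of the chain would read.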